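Iodo for ethyl on the aromatic ring of compound 1

A few compounds are considered here, and "the series" means these few. Any claim that something is new, unique, unknown or untested is made for them only; others in the source may bear on it.

Of the compounds shown here, three have been measured in an assay for binding affinity to adenosine receptor A1 (Bos taurus); on this read-out lower numbers stand for stronger inhibition and higher numbers for weaker inhibition. Compound 1 `CCc1ccc(-c2nc3c(=O)n(C)c(=O)n(C)c3[nH]2)cc1` gives 0.8 nM, the lowest number of the three. Compound 3 `CCn1c(=O)c2nc(-c3ccc(S(=O)(=O)NCCCN(C)C)cc3)[nH]c2n(CC)c1=O` gives 1.6 nM, which lies within the usual scatter of compound 1. Compound 2 `Cn1c(=O)c2nc(-c3ccccc3[N+](=O)[O-])[nH]c2n(C)c1=O` gives 80 nM, well apart from the other two.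

Compound 4 `Cn1c(=O)c2nc(-c3ccc(I)cc3)[nH]c2n(C)c1=O` has not been measured. Relative to compound 1 it differs by iodo in place of ethyl on an aromatic carbon, at a place on an aromatic carbon of a six-membered aromatic ring of carbon only, para to a large group. Going by the values given here, no measured pair covers this change, so no step size is known for it; in this assay a small step is expected, toward a somewhat higher number or none beyond the scatter.

Compound 4 is expected to give 2 nM, between 0.5 nM and 10 nM, which would mean an estimated step of a 2.5-fold higher number from compound 1 to compound 4 (0.40 log units; beyond the scatter).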

Compound 4, half-maximal inhibitory concentration: 1.3 nM
The estimate for compound 4 lay 1.5-fold (0.19 log units) above the measured number; measured number inside the range.
By their numbers in this assay, from the lowest: compounds 1, 4 and 3 (each within the scatter of the next); then compound 2.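

In this assay, iodo in place of ethyl on an aromatic carbon, para to a large group, gives a 1.6-fold higher number from compound 1 to compound 4 (0.21 log units; within the scatter), so this position accepts either group with no step beyond the scatter. Going by these compounds alone, this is the first measured pair that differs in one place, and it gives the series its first step size. No measurement available here bears on what lies behind this result.

From the compounds shown here alone, whether an amine, a carboxylic acid or a longer chain at this carbon would also stay within the scatter remains open. So does the reading for iodo on other carbons of this ring.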